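Methoxy position on the aryl group of compound 2

The source may hold more compounds than are shown below. What is called first, only, known or untested is meant among the compounds shown, and "the series" means these compounds.

Going by the values given here, compound 2 `C=C(Br)C(=O)Nc1cccc(-c2cn3nc(-c4cccc(OC)c4)sc3n2)c1` gives 500 nM in a functional assay on FM3A cells (Mus musculus) for inhibition, read by cell counting, with a stated time of 2 days (on this read-out lower numbers stand for stronger inhibition and higher numbers for weaker inhibition), the lowest of the two numbers measured so far. Compound 1 `C=C(Br)C(=O)Nc1cccc(-c2cn3nc(CCc4ccccc4)sc3n2)c1` gives 2600 nM in this assay; the step of a 5.2-fold lower number from compound 1 to compound 2 (0.72 log units; beyond the scatter) separates the two. Compound 3 `C=C(Br)C(=O)Nc1cccc(-c2cn3nc(-c4ccc(OC)cc4)sc3n2)c1` is unmeasured and differs from compound 2 only in that (4-methoxyphenyl in place of 3-methoxyphenyl on an aromatic carbon). Among the compounds with values here, the single measured step exchanges phenethyl for 3-methoxyphenyl and does not bear on exchanging 3-methoxyphenyl for 4-methoxyphenyl, so no step beyond the scatter is expected in this assay. Compound 3 is therefore estimated at 500 nM in this assay, within 150 nM to 1700 nM, which amounts to an expected no change at the digits printed from compound 2 to compound 3 (within the scatter).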

Compound 3, half-maximal inhibitory concentration: 890 nM
Compound 3: middle estimate off by 1.8-fold (0.25 log units), on the low side, and the stated range covers the measured number.
By their numbers in this assay, from the lowest: compounds 2 and 3 (each within the scatter of the next); then compound 1.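

In this assay the exchange of 3-methoxyphenyl for 4-methoxyphenyl gives a 1.8-fold higher number from compound 2 to compound 3 (0.25 log units; within the scatter) and so does not separate the two methoxy placements on this aromatic carbon. Against phenethyl, the 4-methoxyphenyl group still gives a 2.9-fold lower number from compound 1 to compound 3 (0.47 log units; beyond the scatter), so the separation from compound 1 holds for both methoxyphenyl groups. Nothing available explains these numbers.

Open, from the compounds shown here alone, is whether the methoxy group matters at all on this aryl ring, and how a plain phenyl, a 4-hydroxyphenyl or a 4-aminophenyl would read here.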